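The source may report more compounds than this note shows. Statements on the series, on what has been measured and on what is new or still open speak of the compounds shown alone.

Within the data shown here, compound 1, with the structure `CCOC(=O)C1=C(Nc2ccccc2)S/C(=C\c2ccc(C(=O)O)cc2)C1=O`, is one of two compounds measured in a functional assay on JAR cells (Homo sapiens) for inhibition, read by MTT assay, with a stated time of 72 h, tested at 10 uM (on this read-out higher numbers stand for more inhibition at the one concentration tested (going by the name of the read-out) and lower numbers for less inhibition), where compound 1 gives 16.8%. The other, compound 2, with the structure `CCOC(=O)C1=C(Nc2ccc(OC)c(OC)c2)S/C(=C\c2ccc[nH]2)C1=O`, gives 47.9% in this assay. Compound 1 therefore stands lowest of the two numbers, and the gap to compound 2 lies beyond the usual scatter of such measurements. The next compound, compound 3, with the structure `CCOC(=O)C1=C(Nc2ccccc2)S/C(=C\c2cc3cnccc3[nH]2)C1=O`, has not yet been measured. It differs from compound 1 in one place: a group of 9 heavy atoms (7 carbon, 2 nitrogen; one five-membered aromatic ring with 1 hetero atom, one six-membered aromatic ring with 1 hetero atom) in place of a group of 9 heavy atoms (7 carbon, 2 oxygen; one six-membered aromatic ring of carbon only), on a double-bonded chain carbon bound to a double-bonded ring carbon. Among the measured compounds shown here, no pair of measured compounds shows what such a change does, so the expectation rests only on the two numbers above. Given that compound 2, which also lacks the 4-carboxyphenyl group, gives 47.9%, a step upward of a number 18.2 percentage points higher from compound 1 to compound 3 (beyond the scatter) is expected here. For compound 3 the estimated value in this assay is 35%, with a likely range from 10% to 60%.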

Compound 3, a percentage reported as inhibition, at one concentration (the size of the read-out at that concentration, not a potency): < 10%
Compound 3: a limit, no number (the forecaster's own chance of this, stated with the estimate: 5%); at least 25 percentage points between middle value and limit.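

Compound 3 carries a limit of the assay, not a number: the limit of < 10% in this assay, at which 1 of the 3 values shown sits.

Among these compounds, this is the first direct comparison at the double-bonded chain carbon bound to a double-bonded ring carbon: in this assay, putting the fused two-ring group with its two ring nitrogens in place of 4-carboxyphenyl gives a number at least 6.8 percentage points lower from compound 1 to compound 3 (that floor lies within the scatter). With the rest of the molecule unchanged, this exchange therefore brings no gain in inhibition, although the limit leaves the true size of any loss unknown.

The compounds shown leave open how a simple alkyl chain or a piperidine ring would behave at this place. They also cannot tell whether the five-membered or the six-membered ring of the entering group matters more, since the two always appear together here.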